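The compounds below may be only part of what the source reports. "The series", "measured", "known", "first", "only" and "open" are said of these compounds alone.

Measured so far in a functional assay on A549 cells (Homo sapiens) for cytotoxicity, read by MTT assay, with a stated time of 72 h; a lower number here means a stronger inhibitor, a higher number a weaker inhibitor:
Compound 1 `COc1cccc(/C=C2\CCC/C(=C\c3cccc(Cl)c3)C2=O)c1OC` gives > 20000 nM, a limit of the assay.
Compound 2 `COc1cccc(/C=C2\CCC/C(=C\c3cccc(Br)c3)C2=O)c1OC` gives > 20000 nM, a limit of the assay.
Compound 3 `COc1cccc(/C=C2\CCC/C(=C\c3ccc(Br)cc3)C2=O)c1OC` gives > 20000 nM, a limit of the assay.

Compound 1 thus stands only at a limit in this assay, with no number to place it. Compound 4 `COc1cccc(/C=C2\CCC/C(=C\c3cccc(OC)c3OC)C2=O)c1` differs from compound 1 by methoxy in place of chloro on an aromatic carbon. The measured steps that bear on this change are a step that the two limits leave unreadable from compound 1 to compound 2 and a step that the two limits leave unreadable from compound 1 to compound 3, and neither has a readable size because of the limit of > 20000 nM in this assay, at which 3 of the 3 values shown sit. The third step, a step that the two limits leave unreadable from compound 2 to compound 3, is equally unreadable. No direction for the change to compound 4 can therefore be read from the series, and the expectation is that compound 4 will also sit at the limit in this assay. Compound 4 is estimated at 30000 nM, with a range of 8000 nM to 100000 nM, which is expected to mean a step that the limit leaves unreadable from compound 1 to compound 4.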

Compound 4, half-maximal inhibitory concentration: 16400 nM
Beside the measured number, compound 4's estimate is 1.8-fold (0.26 log units) above it, within the range that was stated.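

Compound 4 is the only compound shown that gives a number rather than a limit in this assay, so methoxy in place of chloro on this aromatic carbon yields the first readable value. The change reads as an at least 1.2-fold lower number from compound 1 to compound 4 (0.08 log units; that floor lies within the scatter), alongside an at least 1.2-fold lower number from compound 2 to compound 4 (0.08 log units; that floor lies within the scatter) and an at least 1.2-fold lower number from compound 3 to compound 4 (0.08 log units; that floor lies within the scatter), so no real gain in strength is established. Each step remains only a floor because one end of it stands at a limit: the limit of > 20000 nM in this assay, at which 3 of the 4 values shown sit.

As far as these compounds go, the true distance between compound 4 and the halogen compounds stays open. Also open, from the compounds shown here alone, is whether an amine or a carboxylic acid on this aromatic carbon would move the number.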